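A Second Chloro Added to the Aryl Ring

The source may hold more compounds than are shown below. What is called first, only, known or untested is meant among the compounds shown, and "the series" means these compounds.

Compound 2 `O=C(NN1CCOCC1)C1=NN(c2ccc(Cl)cc2)C(c2ccccc2)C1` gives 5.6% in a functional assay on the whole organism (strain Zucker) for inhibition, with Rattus norvegicus as the target, with a stated time of 4 h, at a dose of 10 mg/kg by the oral route (a higher number here means more inhibition at the dose given (going by the name of the read-out), a lower number less inhibition), the lower of the two numbers measured, with compound 1 `O=C(NN1CCOCC1)C1=NN(c2ccc(Cl)cc2)C(c2ccc(Cl)cc2)C1` at 8.1% nearby. Among the measured compounds shown here, the one measured step, a number 2.5 percentage points lower from compound 1 to compound 2 (within the scatter), concerns a chloro on the other aromatic ring and stays within the scatter. Compound 3 `O=C(NN1CCOCC1)C1=NN(c2ccc(Cl)cc2Cl)C(c2ccccc2)C1` differs from compound 2 by chloro in place of hydrogen on an aromatic carbon. For the measured compounds named here, with only that small step as a guide, no change beyond the scatter is expected in this assay, and the expected step is a number 1.4 percentage points higher from compound 2 to compound 3 (within the scatter). For compound 3 the estimate is 7%, expected between -3% and 18%.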

Compound 3, a percentage reported as inhibition, in the whole organism at one dose (the size of the read-out at that dose, not a potency): 31.9%
Compound 3: the middle estimate sits 24.9 percentage points below what was measured; measured number outside the range, above it.
By their numbers in this assay, from the lowest: compounds 2 and 1 (each within the scatter of the next); then compound 3.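

In this assay, going from 4-chlorophenyl to 2,4-dichlorophenyl gives a number 26.3 percentage points higher from compound 2 to compound 3 (beyond the scatter) and so shows that this position, ortho to a large group, responds to a chloro. The earlier chloro step on the other aromatic ring stayed within the scatter, so in these compounds the outcome depends on which place carries the chloro. Nothing available explains the rise. Still open, as far as these compounds go, is whether chloro itself is needed here. A fluoro, a methyl or a methoxy at this position would test that.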